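This account rests on a few compounds, and the source may have more. Where it says the series, first, only, none or still open, it means among the compounds named here.

Of the compounds shown here, two of the shared core have so far been measured in a functional assay on WI-38 VA13 cells (Homo sapiens) for cytotoxicity; a higher number here means that more compound is needed for the effect, a lower number that less compound is needed. Compound 1 `Cn1nccc1C(=O)Nc1ccc2nc(NC(=O)C3CCCCC3)sc2c1` gives 0.58 ug/mL in this assay. Compound 2 `O=C(O)CCC(=O)Nc1nc2ccc(NC(=O)c3c(Cl)cccc3Cl)cc2s1` gives only a limit of the assay in this assay, namely > 6.6 ug/mL, so no number is known for it. Compound 2 therefore stands at the limit of > 6.6 ug/mL in this assay, at which 1 of the 2 values shown sits, and nothing in the data places it any closer than that.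

Compound 3 `O=C(NCc1ccccc1)Nc1nc2ccc(NC(=O)c3c(Cl)cccc3Cl)cc2s1` is not yet measured. It differs from compound 2 in one place: benzylamino in place of 2-carboxyethyl on a carbonyl carbon. The change puts a benzylamino group where the 2-carboxyethyl group stood, on a carbonyl carbon whose other neighbour is an amide-type nitrogen, so that the (2-carboxyethyl)carbonyl becomes benzylcarbamoyl.

Going by the values given here, no step between measured compounds is at hand to calibrate such a change, so any expectation rests on the two values alone. Compound 3 is expected to move by a step of an at least 2.2-fold lower number from compound 2 to compound 3 (0.34 log units; beyond the scatter) in this assay, towards a smaller number. Compound 3 is thus estimated at 3 ug/mL, with a range from 1 ug/mL to 9 ug/mL, and with a real chance that the assay again reports only a limit.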

Compound 3, half-maximal effective concentration: 0.15 ug/mL
Estimate against measurement, compound 3: 20-fold (1.30 log units) above, and the stated range ends above it.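

Going by these compounds alone, the change on the carbonyl carbon whose other neighbour is an amide-type nitrogen gives an at least 44-fold lower number from compound 2 to compound 3 (1.64 log units; beyond the scatter) in this assay, the first step that can be read at this place, and it shows that the place is far from indifferent to the group it carries. The change swaps a chain with no ring for a group with one six-membered aromatic ring of carbon only, while both groups carry the same number of hydrogen-bond donors, so a change this large occurs with that count unchanged. Compound 2 is reported only as a limit, so the step gives a bound and not an exact size: the limit of > 6.6 ug/mL in this assay, at which 1 of the 3 values shown sits.

The compounds shown do not separate the aromatic ring of benzylamino, its nitrogen and the loss of the carboxylic acid, as all three change together in this one step. Going by these compounds, whether an ester of that carboxylic acid, a cyclohexylamino group or a longer chain ending in a phenyl ring on the same carbonyl carbon would stand nearer to compound 2 or to compound 3 in this assay remains open.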